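The source may hold more compounds than are shown below. What is called first, only, known or untested is meant among the compounds shown, and "the series" means these compounds.

Compound 1 `O=C(N/N=C/c1ccc(O)cc1)c1cnccn1` and compound 2 `O=C(N/N=C/c1ccccc1)c1cnccn1` share one core and differ in a single spot. In a functional assay on the whole organism (strain Swiss) for inhibition, with Mus musculus as the target, read by paw edema, with stated times of 40 min and 30 min, at a dose of 100 umol/kg by the oral route (a lower number here means less inhibition, a higher number more inhibition at the dose given (going by the name of the read-out)), compound 1 gives 42.3%, while compound 2 gives 30.5%, the lower of the two numbers, a drop of a number 11.8 percentage points lower from compound 1 to compound 2 (beyond the scatter) that came with hydrogen in place of hydroxy on an aromatic carbon. Compound 3 `O=C(N/N=C/c1ccccc1O)c1cnccn1` brings a hydroxy back, now on an aromatic carbon ortho to a large group: hydroxy in place of hydrogen on an aromatic carbon. On these data alone, that single measured step suggests adding a hydroxy could lift inhibition modestly, though the new position is untested. Compound 3 is expected to give 38%, ranging from 26% to 50%. This estimate implies a step of a number 7.5 percentage points higher from compound 2 to compound 3 (within the scatter).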

Compound 3, a percentage reported as inhibition, in the whole organism at one dose (the size of the read-out at that dose, not a potency): 42%
Beside the measured number, compound 3's estimate is 4 percentage points below it; the measured number falls inside the stated range.
By their numbers in this assay, from the lowest: compound 2; then compounds 3 and 1 (each within the scatter of the next).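

Hydroxy ortho to a large group also lifts the number in this assay, with a number 11.5 percentage points higher from compound 2 to compound 3 (beyond the scatter), so the rise is not confined to the hydroxy placement of compound 1. Compound 1 and compound 3 lie within the scatter of each other, so these two hydroxy placements cannot be told apart here.

On these data alone, whether an amine or a methoxy group in this place would match hydroxy remains open. Nothing shown explains why hydroxy changes the paw edema result.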